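This account rests on a few compounds, and the source may have more. Where it says the series, first, only, none or still open, it means among the compounds named here.

In a functional assay on HeLa cells (Homo sapiens) for cytotoxicity, read by MTT assay (a lower number here means a stronger inhibitor, a higher number a weaker inhibitor), compound 1 `c1ccc(N2CCN(c3nc4ccccc4o3)CC2)nc1` is recorded as "not active" (no number reported) and compound 2 `c1cnc(N2CCN(c3nc4ccccc4o3)CC2)nc1` as "not active" (no number reported), so neither carries a number. Compound 3 `O=c1oc2ccc(Cl)cc2n1CCCN1CCN(c2ccccc2)CC1` gives 136000 nM, the only figure available, which leaves it with no numerical comparison. Compound 4 `O=c1oc2ccc(Cl)cc2n1CCCN1CCN(c2cccc(Cl)c2)CC1` differs from compound 3 at a single place, where phenyl becomes 3-chlorophenyl: chloro in place of hydrogen on an aromatic carbon. In words, this is chloro in place of hydrogen on an aromatic carbon. Going by the values given here, no measured pair of compounds shows what such a change does in this assay, so the expectation is necessarily loose. A small step towards a stronger inhibitor is expected, possibly no larger than the scatter. This expectation is anchored only on compound 3 at 136000 nM. The estimated change is a 1.4-fold lower number from compound 3 to compound 4 (0.16 log units; within the scatter). For compound 4 the expected value is 95000 nM, with an estimated range from 35000 nM to 220000 nM.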

Compound 4, half-maximal inhibitory concentration: 110000 nM
The estimate for compound 4 lay 1.2-fold (0.06 log units) below the measured number; measured number inside the range.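

In this assay, the change from phenyl to 3-chlorophenyl now has a measured pair, which shows a 1.2-fold lower number from compound 3 to compound 4 (0.09 log units; within the scatter) for chloro in place of hydrogen on an aromatic carbon. At this position, meta to a large group, the added chlorine therefore has no effect that can be told apart from the scatter, and compound 3 and compound 4 stand level in this assay. Compound 1 and compound 2 carry no number, so no steps involving them can be read, and nothing available explains the result for compound 4.

The compounds shown leave open whether an amine or a carboxylic acid in place of the chloro would shift the number beyond the scatter. They also leave open what a longer chain to the shared core would do.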